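The source may report more compounds than this note shows. Statements on the series, on what has been measured and on what is new or still open speak of the compounds shown alone.

Measured so far:
- compound 1 `CCOC(=O)c1nnn(-c2cccc(NC(=O)c3ccc(/C=C/C(=O)c4ccc(Cl)cc4)cc3)c2)c1C`, in an ADME assay on Vero cells (Chlorocebus sabaeus) for cytotoxicity, read by MTT assay, with a stated time of 72 h (a higher number here means that more compound is tolerated, a lower number that less compound is tolerated), compound 1 gives "not determined" (no result reported)
- compound 2 `COC(=O)c1cc(-c2cccc(NC(=O)c3ccc(/C=C/C(=O)c4ccc(Br)cc4)cc3)c2)on1`, compound 2 gives > 20 ug/mL
- compound 3 `COC(=O)c1cc(-c2ccc(NC(=O)c3ccc(/C=C/C(=O)c4ccc(Cl)cc4)cc3)cc2)on1`, compound 3 gives > 80 ug/mL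

Compound 2 stands not at a number but at a limit of this assay, (the limit of > 20 ug/mL in this assay, at which 1 of the 3 values shown sits). Compound 3 also sits at a limit, (the limit of > 80 ug/mL in this assay, at which 1 of the 3 values shown sits). Compound 1 has no result in this assay. Within the data shown here, of the three, only two carry a reading, and both are limits, so no step between measured compounds can be set out and no spread of tolerated concentrations is visible among them.

Compound 4 `COC(=O)c1cc(-c2cccc(NC(=O)c3ccc(/C=C/C(=O)c4ccc(CC(C)C)cc4)cc3)c2)on1` differs from compound 2 in one place: isobutyl in place of bromo on an aromatic carbon. Among the measured compounds shown here, with nothing measured on either side of this change, the expected step in this assay is a step that the limit leaves unreadable from compound 2 to compound 4, which is none beyond the usual scatter; the one reading on compound 2, > 20 ug/mL, is only a limit and sets the floor of the expectation. Compound 4 is therefore expected to give about 40 ug/mL in this assay, with a likely range from 15 ug/mL to 100 ug/mL, and a good chance that only a limit is reported.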

Compound 4, half-maximal cytotoxic concentration: > 10 ug/mL
Compound 4 ended at the assay's limit (the forecaster's own chance of this, stated with the estimate: 65%); the middle value lies beyond the limit too.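

Among these compounds, compound 2 and compound 4 both carry only limits in this assay, and no step between them can be read. The compounds shown leave open what concentration any of them actually tolerates, and whether isobutyl in place of bromo changes it at all.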